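Swapping methyl for chloro on the benzyl group

The source may report more compounds than this note shows. Statements on the series, on what has been measured and on what is new or still open speak of the compounds shown alone.

Measured compounds:
Compound 1, `O=C1Nc2ccc(Cl)cc2/C1=N/NC(=S)Nc1ccc(Cl)cc1`: 64000 nM
Compound 2, `Cc1ccc(CN2C(=O)/C(=N\NC(=S)Nc3ccc(Cl)cc3)c3cc(Cl)ccc32)cc1`: 5800 nM

Both compounds were tested in a functional assay on MOLT-4 cells (Homo sapiens), with a stated time of 72 h; a higher number here means a weaker inhibitor, a lower number a stronger inhibitor. Compound 2 holds the lowest number of the two, and its nearest neighbour is compound 1, reached by the step of an 11-fold lower number from compound 1 to compound 2 (1.04 log units; beyond the scatter), which is a large change that came from putting 4-methylbenzyl in place of hydrogen on an amide-type nitrogen in a ring.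

Compound 3, `O=C1/C(=N\NC(=S)Nc2ccc(Cl)cc2)c2cc(Cl)ccc2N1Cc1ccc(Cl)cc1`, has not yet been measured in this assay. It differs from compound 2 in one place: chloro in place of methyl on an aromatic carbon. Within the data shown here, the only measured step, from compound 1 to compound 2, concerns the presence of the whole benzyl group rather than the group at its far end, so it gives no direct guide to what a chloro in place of a methyl will do. Among the measured compounds shown here, with no step bearing on this exact change, the expectation is that compound 3 stays close to compound 2, with a step of a 1.2-fold lower number from compound 2 to compound 3 (0.06 log units; within the scatter), which lies within the scatter. Compound 3 is therefore estimated at 5000 nM, with a range from 2000 nM to 15000 nM.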

Compound 3, half-maximal inhibitory concentration: 58000 nM
For compound 3 the middle estimate is 12-fold (1.06 log units) below the measured one; measured number outside the range, above it.
By their numbers in this assay, from the lowest: compound 2; then compounds 3 and 1 (each within the scatter of the next).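

At the far end of the benzyl group, one atom decides the outcome: in this assay the swap gives a 10-fold higher number from compound 2 to compound 3 (1.00 log units; beyond the scatter), so the group on this aromatic carbon, para to a large group, matters as well as the presence of the benzyl group. The chloro version also brings no clear gain over the bare amide hydrogen, with a 1.1-fold lower number from compound 1 to compound 3 (0.04 log units; within the scatter), so the earlier step of an 11-fold lower number from compound 1 to compound 2 (1.04 log units; beyond the scatter) belongs to 4-methylbenzyl in particular and cannot be credited to benzyl groups in general. Nothing among the data given accounts for this difference between methyl and chloro.

From the compounds shown here alone, with only methyl and chloro at this place, it remains open whether the methyl is what helps or the chloro is what cancels the gain, and a benzyl group with plain hydrogen there would separate those two readings. A fluoro, a methoxy or an ethyl at the same place would further show whether compound 2 or compound 3 is the more typical case.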